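A Propanoyl Amide Tested for Cytotoxicity on Vero Cells

The compounds below may be only part of what the source reports. "The series", "measured", "known", "first", "only" and "open" are said of these compounds alone.

Compound 1 `CCN(CC)CC(=O)Nc1ccc(-c2nc3cc(C(F)(F)F)ccc3n2C)cc1` was examined in an ADME assay on Vero cells (Chlorocebus sabaeus) for cytotoxicity (on this read-out lower numbers stand for higher toxicity in this test and higher numbers for lower toxicity in this test), where compound 1 gives 90000 nM. Going by the values given here, that is the only number among the three results for this series. Compound 2 `O=C(CN1CCCCC1)Nc1ccc(-c2nc3cc(Cl)c(Cl)cc3[nH]2)cc1` reaches a limit of the test, > 100000 nM. Compound 3 `Oc1ccc(-c2nc3cc(C(F)(F)F)ccc3[nH]2)cc1` likewise stops at a limit, > 100000 nM. Among the compounds with values here, compound 1 therefore stands at the single measured value, close to the limit of > 100000 nM in this assay, at which 2 of the 3 values shown sit. Compound 4 `CCC(=O)Nc1ccc(-c2nc3cc(C(F)(F)F)ccc3n2C)cc1` has not yet been measured in this assay. It differs from compound 1 in one place: methyl in place of diethylamino on a saturated chain carbon bound to a carbonyl carbon. Within the data shown here, no step between measured compounds is available, so the expectation for compound 4 rests on the position of compound 1 near the limit alone. The step of a 1.1-fold higher number from compound 1 to compound 4 (0.05 log units; within the scatter) is expected to lie within the scatter, with no clear direction. For compound 4 the half-maximal cytotoxic concentration in this assay is estimated at 100000 nM, within a range from 40000 nM to 300000 nM, with a fair chance that only a limit is reported.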

Compound 4, half-maximal cytotoxic concentration: > 100000 nM
Compound 4: only a limit was reported (the forecaster's own chance of this, stated with the estimate: 50%); the middle value lies on the limit itself.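

In this assay, going by these compounds alone, a change on the saturated chain carbon bound to a carbonyl carbon can now be read for the first time, and replacing diethylamino with methyl gives an at least 1.1-fold higher number from compound 1 to compound 4 (0.04 log units; that floor lies within the scatter). The earlier compounds shown here offered no such step, and this one shows no toxicity in this test that can be tied to the diethylamino group, as the floor of the step lies within the scatter. The value of compound 4 is only a limit, so the true size of the step stays unknown, and the compound joins the others there: the limit of > 100000 nM in this assay, at which 3 of the 4 values shown sit.

The compounds shown leave open whether a carboxylic acid, a primary amine or a longer chain than propanoyl at this position would bring the number down from the limit. They also leave open whether the same change would read alike on a core carrying a free ring hydrogen in place of the methyl of compound 1.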